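A Bromine on the Styryl Ring of Compound 3

The source may hold more compounds than are shown below. What is called first, only, known or untested is meant among the compounds shown, and "the series" means these compounds.

Compound 3 `NS(=O)(=O)c1cc(-c2nnc(/C=C/c3ccccc3)o2)c(Cl)cc1SCc1ccccc1` holds the lowest number of the three compounds measured in a functional assay on HeLa cells (Homo sapiens) for cytotoxicity, read by MTT assay, with a stated time of 72 h (a higher number here means a weaker inhibitor, a lower number a stronger inhibitor), where compound 3 gives 14000 nM. Compound 1 `[N-]=[N+]=NCc1nnc(-c2cc(S(N)(=O)=O)c(SCc3ccccc3)cc2Cl)o1` gives 115000 nM and compound 2 `CCOC(=O)c1cn(Cc2nnc(-c3cc(S(N)(=O)=O)c(SCc4ccccc4)cc3Cl)o2)nn1` gives 122000 nM; the step of an 8.2-fold lower number from compound 1 to compound 3 (0.91 log units; beyond the scatter) and the step of an 8.7-fold lower number from compound 2 to compound 3 (0.94 log units; beyond the scatter) are both beyond the scatter, so compound 3 is the strongest inhibitor of the three, while a 1.1-fold higher number from compound 1 to compound 2 (0.03 log units; within the scatter) lies within it.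

Compound 4 `NS(=O)(=O)c1cc(-c2nnc(/C=C/c3ccc(Br)cc3)o2)c(Cl)cc1SCc1ccccc1` differs from compound 3 by bromo in place of hydrogen on an aromatic carbon. Among the measured compounds shown here, none of the measured steps touches this outer ring: the two steps that reach compound 3 exchange the whole group on the shared core for a 2-phenylethenyl group, and no measured compound carries a substituent on that phenyl. They show that the 2-phenylethenyl group itself brings the modest gains seen against compound 1 and compound 2, but they give no guide to a bromo placed para to a large group on it. The step expected here, a 1.4-fold lower number from compound 3 to compound 4 (0.15 log units; within the scatter), is therefore one that stays within the scatter, leaning only slightly toward a lower number. Compound 4 is estimated at 10000 nM in this assay, in the range 4000 nM to 28000 nM.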

Compound 4, half-maximal inhibitory concentration: 29000 nM
For compound 4 the middle estimate is 2.9-fold (0.46 log units) below the measured one, and the stated range ends below it.
By their numbers in this assay, from the lowest: compound 3; then compound 4; then compounds 1 and 2 (each within the scatter of the next).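

In this assay, the outer phenyl ring of the 2-phenylethenyl group now has a measured substituent, and the change runs against the lean of the earlier picture: the step is a 2.1-fold higher number from compound 3 to compound 4 (0.32 log units; beyond the scatter). A bromo on this aromatic carbon, para to a large group, therefore gives back a modest part of the advantage held by the unsubstituted group, though it does not remove that advantage, since the 2-(4-bromophenyl)ethenyl group still gives a 4.2-fold lower number from compound 2 to compound 4 (0.62 log units; beyond the scatter) and a 4.0-fold lower number from compound 1 to compound 4 (0.60 log units; beyond the scatter). Nothing available explains why the number rises when bromo replaces hydrogen at this place.

The compounds shown leave open whether this rise belongs to bromine in particular or would also follow from another group at the same place, such as fluoro, methoxy, an amine or a carboxylic acid. They also leave open whether bromo at another carbon of this ring would give a similar step, and whether the same step would appear on cells other than those of this single assay.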